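The source may hold more compounds than are shown below. What is called first, only, known or untested is meant among the compounds shown, and "the series" means these compounds.

Measured compounds:
Compound 1 `COc1cc2nc(/C=C\c3ccncc3)c(=O)n(CC(=O)Nc3ccccc3)c2cc1OC` gives 55700 nM in a functional assay on cells (Homo sapiens) for inhibition, read by MTT assay, with a stated time of 24 h; a higher number here means a weaker inhibitor, a lower number a stronger inhibitor.
Compound 2 `O=C(COc1nc2ccccc2nc1/C=C\c1ccncc1)Nc1ccc(Cl)cc1` reaches only the limit of this assay, reported as > 100000 nM.
Compound 3 `Cc1ccc(C(=O)Nc2ccc(Cn3c(=O)c(C)nc4ccccc43)cc2)cc1` likewise reaches only the limit of this assay, reported as > 100000 nM.

Compound 3 therefore stands at the limit, and it does not stand there alone: the limit of > 100000 nM in this assay, at which 2 of the 3 values shown sit. Only compound 1 gives a number at all, and that number sits far toward the weak end of the range shown. For compound 3, the reading says only that it is a limit, and no number can be placed on it.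

The unmeasured compound 4 `Cc1nc2ccccc2n(Cc2ccc(NC(=O)c3ccc(Cl)cc3)cc2)c1=O` differs from compound 3 in one place: chloro in place of methyl on an aromatic carbon, para to a large group, so that the 4-methylphenyl becomes a 4-chlorophenyl and the (4-methylphenyl)carbonyl a (4-chlorophenyl)carbonyl. No measured step of this kind is shown among the three compounds, so the expectation can rest only on where compound 3 stands. Since compound 3 is already at the limit, the expected step that the limit leaves unreadable from compound 3 to compound 4 is none beyond the scatter, with a fair chance that compound 4 is again reported only as a limit. Compound 4 is thus estimated at 120000 nM, in a range from 40000 nM to 400000 nM.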

Compound 4, half-maximal inhibitory concentration: > 100000 nM
Compound 4: only a limit was reported; the forecaster's own chance of this, stated with the estimate: 70%; the middle value does not contradict the limit.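

No step can be read from compound 3 to compound 4, since both are reported only as limits in this assay: the limit of > 100000 nM in this assay, at which 3 of the 4 values shown sit. The compounds shown leave open whether chloro in place of methyl on an aromatic carbon changes inhibition at all, and how compound 3 and compound 4 would compare if either gave a number.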